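Acylguanidine series: aryl-sulfanyl variation at the sulfonyl-bearing ring

This account rests on a few compounds, and the source may have more. Where it says the series, first, only, none or still open, it means among the compounds named here.

Measured compounds, a functional assay for inhibition of sodium/hydrogen exchanger (Oryctolagus cuniculus); on this read-out lower numbers stand for stronger inhibition and higher numbers for weaker inhibition:
compound 1, `Cc1cc(C2CCCCC2)c(S(C)(=O)=O)cc1C(=O)N=C(N)N`, 22 nM
compound 2, `Cc1cc(-c2ccc(Cl)cc2Cl)c(S(C)(=O)=O)cc1C(=O)N=C(N)N`, 42 nM
compound 3, `Cc1cc(Sc2ccc(Cl)cc2)c(S(C)(=O)=O)cc1C(=O)N=C(N)N`, 19 nM

Compound 3 gives the lowest of the three numbers in this assay. Its nearest neighbour is compound 1, and the step of a 1.2-fold lower number from compound 1 to compound 3 (0.06 log units; within the scatter) lies within the scatter, so the two cannot be ordered. The step of a 2.2-fold lower number from compound 2 to compound 3 (0.34 log units; beyond the scatter) is modest but beyond the scatter, and a 1.9-fold higher number from compound 1 to compound 2 (0.28 log units; within the scatter) stays within it.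

Compound 4, `Cc1cc(Sc2ccncc2)c(S(C)(=O)=O)cc1C(=O)N=C(N)N`, differs from compound 3 by pyridin-4-yl in place of 4-chlorophenyl on a sulfur. For the measured compounds named here, none of the measured steps exchanges one six-membered aromatic ring for another while keeping the sulfur link, so no step bears on this change directly. What the three measured compounds do show is that replacing the whole substituent on that aromatic carbon, whether by cyclohexyl, by 2,4-dichlorophenyl or by (4-chlorophenyl)sulfanyl, moves the number by no more than the modest 2.2-fold lower number from compound 2 to compound 3 (0.34 log units; beyond the scatter). The expectation for compound 4 in this assay is therefore a step of about a 1.6-fold higher number from compound 3 to compound 4 (0.20 log units; within the scatter), toward a slightly higher number and at the edge of the scatter. Compound 4 is estimated at 30 nM, with a range from 10 nM to 90 nM.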

Compound 4, half-maximal inhibitory concentration: 13 nM
Estimate against measurement, compound 4: 2.3-fold (0.36 log units) above; the measured number falls inside the stated range.
By their numbers in this assay, from the lowest: compounds 4, 3, 1 and 2 (each within the scatter of the next, the first and the last beyond it).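

In this assay, the sulfur tolerates pyridin-4-yl in place of 4-chlorophenyl: a 1.5-fold lower number from compound 3 to compound 4 (0.16 log units; within the scatter) gives no readable change on exchanging a carbon-only ring bearing chlorine for a ring with a hetero atom and a hydrogen-bond acceptor. The (pyridin-4-yl)sulfanyl group also separates from 2,4-dichlorophenyl on the aromatic carbon by a 3.2-fold lower number from compound 2 to compound 4 (0.51 log units; beyond the scatter), a modest step that is larger than the one seen with (4-chlorophenyl)sulfanyl, while a 1.7-fold lower number from compound 1 to compound 4 (0.23 log units; within the scatter) leaves it unordered against cyclohexyl, so the series at this position still spans only a narrow band of numbers. No measurement available here accounts for any of these steps.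

Open, as far as these compounds go, is whether the chlorine or the ring nitrogen has any separate bearing on the number, which a plain phenyl on the sulfur would help to address, and whether the sulfur link itself matters, which pyridin-4-yl placed directly on the aromatic carbon would test. Also open, from the compounds shown here alone, is how far this tolerance extends, for instance to an amine or a carboxylic acid carried on the sulfur-linked ring.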